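Swapping the amide substituent on a cinnamate glycolamide

The compounds below may be only part of what the source reports. "The series", "measured", "known", "first", "only" and "open" are said of these compounds alone.

Among the measured compounds shown here, compound 1 `COCOc1cc(/C=C/C(=O)OCC(=O)NN2CCOCC2)ccc1OCc1ccccc1` is the only member of this set with a numerical result in a functional assay on HL-60 cells (Homo sapiens) for cytotoxicity, read by MTT assay, with a stated time of 72 h (on this read-out higher numbers stand for weaker inhibition and lower numbers for stronger inhibition), where compound 1 gives 50400 nM. Compound 2 `CCOc1ccc(COc2c(OC)cc(/C=C/C(=O)OCC(=O)Nc3ccccc3)cc2OC)cc1` returns only a limit in this assay, > 200000 nM, and that is the limit of > 200000 nM in this assay, at which 1 of the 2 values shown sits. Compound 3 `COCOc1cc(/C=C/C(=O)OCC(=O)NCc2ccco2)ccc1OCc1ccccc1` carries (furan-2-yl)methyl in place of morpholin-4-yl on an amide-type nitrogen. For the measured compounds named here, no measured step of this kind is available, so no direction is expected beyond the scatter. Compound 3 is therefore expected near 50000 nM, with a range from 15000 nM to 170000 nM. The step of a 1.0-fold lower number from compound 1 to compound 3 (0.00 log units; within the scatter) is estimated to stay within the usual scatter.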

Compound 3, half-maximal inhibitory concentration: 82200 nM
For compound 3 the middle estimate is 1.6-fold (0.22 log units) below the measured one, within the range that was stated.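

At the amide-type nitrogen of the shared core, (furan-2-yl)methyl in place of morpholin-4-yl gives a 1.6-fold higher number from compound 1 to compound 3 (0.21 log units; within the scatter) in this assay. A five-membered aromatic ring and a six-membered non-aromatic ring with 2 hetero atoms thus read alike at this position in this read-out. No measurement shown here bears on why they do.

From the compounds shown here alone, what stays open is whether a benzyl group, a longer alkyl chain or a carboxylic acid on this nitrogen would also stay within the scatter of compound 1. The step is also shown on this one core only.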